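The compounds below may be only part of what the source reports. "The series", "measured", "known", "first", "only" and "open" are said of these compounds alone.

In a functional assay on Jurkat cells (Homo sapiens) for inhibition, read by CCK-8 assay, with a stated time of 48 h (on this read-out lower numbers stand for stronger inhibition of growth and higher numbers for weaker inhibition of growth), compound 1 (`Cc1ccccc1Nc1nc(NC2CC2)ncc1Cl`) gives > 100000 nM as a limit of the assay. Compound 2 (`Cc1ccc(Nc2ncc(Cl)c(Nc3ccccc3C)n2)cc1`) gives > 100000 nM, also a limit. Compound 3 (`CN1CCN(c2ccc(Nc3ncc(Cl)c(NCc4ccc(F)cc4)n3)nc2)CC1`) stands only at the limit > 100000 nM and has no number. Compound 4 (`Cc1cccc(Nc2nc(Nc3ccc(N4CCN(C)CC4)cn3)ncc2Cl)c1`) carries 3-methylphenyl in place of 4-fluorobenzyl on a nitrogen on an aromatic ring. Among the measured compounds shown here, the one measured step is a step that the two limits leave unreadable from compound 1 to compound 2, so it offers no size to carry over. For the measured compounds named here, the series so far shows only (the limit of > 100000 nM in this assay, at which 3 of the 3 values shown sit). In this assay a modest move toward stronger inhibition of growth is expected at best, and another limit is quite possible. The expected change is an at least 2.5-fold lower number from compound 3 to compound 4 (0.39 log units; beyond the scatter). For compound 4 the estimate is 40000 nM, with an expected range from 3000 nM to 100000 nM.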

Compound 4, concentration for 50% growth inhibition: 15300 nM
Compound 4: the middle estimate sits 2.6-fold (0.42 log units) above what was measured; measured number inside the range.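

In this assay, among the compounds shown here, 3-methylphenyl in place of 4-fluorobenzyl on a nitrogen on an aromatic ring gives an at least 6.5-fold lower number from compound 3 to compound 4 (0.81 log units; beyond the scatter), the first readable step. The size is a floor, as compound 3 has only a limit. Compound 4 is the only compound shown with a number: the limit of > 100000 nM in this assay, at which 3 of the 4 values shown sit.

Still open, on these data alone, is whether the gain follows the methyl group, the loss of fluorine, or the shorter link to the ring. As far as these compounds go, it is also open how an unsubstituted phenyl or a longer chain on this nitrogen would read.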